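A few compounds are considered here, and "the series" means these few. Any claim that something is new, unique, unknown or untested is made for them only; others in the source may bear on it.

Compound 1 `CC(=O)c1cccc(-c2ccc(C(=O)N(Cc3cccc(OCCCCCC(=O)O)c3)C(C)C)cc2)c1` is the starting point. In an ADME assay on BJ cells (Homo sapiens) for cytotoxicity, read by CellTiter-Glo and resazurin assay, with a stated time of 72 h (on this read-out lower numbers stand for an effect already at smaller amounts and higher numbers for an effect only at larger amounts of compound), compound 1 gives > 26000 nM, which is a limit of the measurement rather than a number. Compound 2 `CC(C)COc1cccc(-c2ccc(C(=O)N(Cc3cccc(OCCCCCC(=O)O)c3)C(C)C)cc2)c1` gives > 26000 nM in this assay, again only a limit. Compound 3 `CC(C)N(Cc1cccc(OCCCCCC(=O)O)c1)C(=O)c1ccc(-c2ccsc2)cc1` gives > 26000 nM in this assay, also a limit. Because of the limit of > 26000 nM in this assay, at which 3 of the 3 values shown sit, none of the steps among these three can be sized: a step that the two limits leave unreadable from compound 1 to compound 2, a step that the two limits leave unreadable from compound 1 to compound 3 and a step that the two limits leave unreadable from compound 2 to compound 3 all stay unreadable.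

Compound 4 `CCOc1cccc(-c2ccc(C(=O)N(Cc3cccc(OCCCCCC(=O)O)c3)C(C)C)cc2)c1` differs from compound 1 by ethoxy in place of acetyl on an aromatic carbon, so the 3-acetylphenyl of compound 1 becomes a 3-ethoxyphenyl. For the measured compounds named here, the closest measured change is the one from compound 1 to compound 2, which swaps the same acetyl for an isobutoxy, and its size is unreadable. Going by the values given here, no measured step therefore points to a direction, and the expected step that the limit leaves unreadable from compound 1 to compound 4 in this assay is no effect within the tested range. Compound 4 is estimated at 40000 nM in this assay, between 15000 nM and 120000 nM, most likely reported again only as a limit.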

Compound 4, half-maximal effective concentration: > 20800 nM
Compound 4: a limit, no number; the forecaster's own chance of this, stated with the estimate: 85%; the middle value is on the limit's open side.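

In this assay compound 4 gives > 20800 nM, again a limit and not a number. Its steps to compound 1, compound 2 and compound 3 therefore cannot be read. The compounds shown leave open at what concentration any of these four takes effect, and whether swapping these groups changes that concentration.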